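Pruning the side chain of compound 1 to a methoxy

A few compounds are considered here, and "the series" means these few. Any claim that something is new, unique, unknown or untested is made for them only; others in the source may bear on it.

The shared core carries a difluorobenzyl-substituted oxazole linked through an amine to a phenyl ring, and three members have been measured. Compound 1 `Fc1cccc(F)c1Cc1cnc(Nc2ccc(CCOc3ccncc3)cc2)o1` gives 11000 nM in an ADME assay on MT2 cells (Homo sapiens) for cytotoxicity, read by MTT assay; on this read-out higher numbers stand for lower toxicity in this test and lower numbers for higher toxicity in this test. Compound 2 `Fc1cccc(F)c1Cc1cnc(Nc2ccc(Oc3cccnc3)c(Cl)c2)o1` gives 16000 nM in this assay, and compound 3 `Fc1cccc(F)c1Cc1cnc(Nc2ccc(Oc3cccnc3)c(Br)c2)o1` gives 7500 nM; between these two, bromo in place of chloro on an aromatic carbon brings a 2.1-fold lower number from compound 2 to compound 3 (0.33 log units; beyond the scatter). Among the three numbers, compound 1 stands second highest, but its gaps to compound 2 and to compound 3 are both within the scatter of such measurements.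

Compound 4 `COCc1ccc(Nc2ncc(Cc3c(F)cccc3F)o2)cc1` differs from compound 1 by methoxy in place of ((pyridin-4-yl)oxy)methyl on a saturated chain carbon bound to an aromatic carbon. Going by the values given here, the only measured step concerns a halogen swap on a different part of the molecule, so no measured step bears on this change, and the three values all cluster closely. The expected step is therefore no change at the digits printed from compound 1 to compound 4 (within the scatter), none beyond the scatter. Compound 4 is expected to give 11000 nM, within a range from 4500 nM to 27000 nM.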

Compound 4, half-maximal cytotoxic concentration: 32000 nM
Compound 4: the middle estimate sits 2.9-fold (0.46 log units) below what was measured; measured number outside the range, above it.
By their numbers in this assay, from the lowest: compounds 3, 1, 2 and 4 (each within the scatter of the next, the first and the last beyond it).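

Compound 1 and compound 4 differ only in the side chain, and in this assay this change gives a 2.9-fold higher number from compound 1 to compound 4 (0.46 log units; beyond the scatter). The side chain is therefore not a silent position: replacing ((pyridin-4-yl)oxy)methyl, with its eight heavy atoms and pyridine ring, by methoxy, with two heavy atoms and no ring, moves the result towards lower toxicity in this test, a step that the halogen swap elsewhere on the molecule could not reveal. Nothing available explains this step.

From the compounds shown here alone, it remains open whether the step follows the loss of the pyridine ring or the shortening of the chain, since the two change together here. A phenoxy group or a dimethylamino group on the same saturated chain carbon would help to separate these two readings.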